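From trichlorophenyl to methylphenyl on the shared core

The source may report more compounds than this note shows. Statements on the series, on what has been measured and on what is new or still open speak of the compounds shown alone.

Measured in a functional assay on HCT-116 cells (Homo sapiens) for antiproliferative activity, read by MTT assay, with a stated time of 72 h; on this read-out lower numbers stand for stronger inhibition and higher numbers for weaker inhibition
Compound 1 (`Cc1cc(C)cc(OCCCON2C(N)=NC(N)=NC23CCOCC3)c1`) gives 190 nM
Compound 2 (`NC1=NC2(CCOCC2)N(OCCCOc2ccc(Cl)cc2Cl)C(N)=N1`) gives 880 nM
Compound 3 (`NC1=NC2(CCOCC2)N(OCCCOc2cc(Cl)c(Cl)cc2Cl)C(N)=N1`) gives 2750 nM

Compound 3 has the highest number of the three, which makes it the weakest inhibitor among them. Compound 4 (`Cc1ccc(OCCCON2C(N)=NC(N)=NC23CCOCC3)cc1`) differs from it in one place, with 4-methylphenyl in place of 2,4,5-trichlorophenyl on an oxygen on a saturated carbon. The nearest guide is a large step, a 14-fold higher number from compound 1 to compound 3 (1.16 log units; beyond the scatter) when 2,4,5-trichlorophenyl replaces 3,5-dimethylphenyl. A modest step, a 3.1-fold higher number from compound 2 to compound 3 (0.49 log units; beyond the scatter) for one added chloro, points the same way. For the measured compounds named here, no measured step separates 4-methylphenyl from 3,5-dimethylphenyl. In this assay a large step to a lower number is therefore expected. That means an estimated 7.9-fold lower number from compound 3 to compound 4 (0.90 log units; beyond the scatter) for this change. Compound 4 is expected at 350 nM with 120 nM to 1000 nM as its estimated range.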

Compound 4, half-maximal inhibitory concentration: 2390 nM
The estimate for compound 4 lay 6.8-fold (0.83 log units) below the measured number, outside the stated range (above it).
By their numbers in this assay, from the lowest: compound 1; then compound 2; then compounds 4 and 3 (each within the scatter of the next).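

In this assay the change at this position gives a 1.2-fold lower number from compound 3 to compound 4 (0.06 log units; within the scatter) so losing the chloro groups alone does not bring the number near that of compound 1. The same group gives a 2.7-fold higher number from compound 2 to compound 4 (0.43 log units; beyond the scatter) and a 13-fold higher number from compound 1 to compound 4 (1.10 log units; beyond the scatter) so among these compounds the low number goes with 3,5-dimethylphenyl and not with a methyl-bearing ring as such. No measurement shown here gives a reason for this.

As far as these compounds go, whether 3,5-dichlorophenyl would give a number close to that of compound 1 stays open. So does the effect of a longer chain between the two oxygens.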